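Chloro to bromo on the pendant phenyl: cytotoxicity outlook

A few compounds are considered here, and "the series" means these few. Any claim that something is new, unique, unknown or untested is made for them only; others in the source may bear on it.

Measured compounds:
- compound 1, `N#Cc1c(-c2ccc(O)cc2)c(C#N)c(=O)n(/N=C/c2cn(-c3ccccc3)nc2-c2ccccc2)c1N`, in an ADME assay on HeLa cells (Homo sapiens) for cytotoxicity, read by MTT assay (a lower number here means a stronger inhibitor, a higher number a weaker inhibitor), gives > 200 ug/mL, a limit of the assay.
- compound 2, `N#Cc1c(-c2ccc(Cl)cc2)c(C#N)c(=O)n(/N=C/c2cn(-c3ccccc3)nc2-c2ccccc2)c1N`, gives > 200 ug/mL, a limit of the assay.
- compound 3, `N#Cc1c(-c2ccc([N+](=O)[O-])cc2)c(C#N)c(=O)n(/N=C/c2cn(-c3ccccc3)nc2-c2ccccc2)c1N`, gives > 200 ug/mL, a limit of the assay.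

Compound 2 stands where every measured member of the series stands: at the limit of > 200 ug/mL in this assay, at which 3 of the 3 values shown sit. No number separates compound 2 from either neighbour; the values that surround it are also limits.

The step to compound 4, `N#Cc1c(-c2ccc(Br)cc2)c(C#N)c(=O)n(/N=C/c2cn(-c3ccccc3)nc2-c2ccccc2)c1N`, is bromo in place of chloro on an aromatic carbon.

The measured steps that bear on this change are a step that the two limits leave unreadable from compound 1 to compound 2, a step that the two limits leave unreadable from compound 1 to compound 3 and a step that the two limits leave unreadable from compound 2 to compound 3. Each is unreadable in size, since both ends sit at the limit. Hydroxy, chloro and nitro on this aromatic carbon therefore all leave the read-out at the limit, and no direction of change can be read from them. For bromo at the same place no reason appears to expect a departure from that picture.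

Compound 4 is expected at 300 ug/mL, with a range from 150 ug/mL to 1000 ug/mL. The expected step is a step that the limit leaves unreadable from compound 2 to compound 4, most likely again only a limit.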

Compound 4, half-maximal inhibitory concentration: > 200 ug/mL
Compound 4: no number, only a limit; the forecaster's own chance of this, stated with the estimate: 90%; the middle value does not contradict the limit.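

No new step can be read: compound 4 joins compound 1, compound 2 and compound 3 at a limit of this assay, so its steps to all three cannot be read. The series sits at one limit: the limit of > 200 ug/mL in this assay, at which 4 of the 4 values shown sit. The compounds shown leave open how these four compare and whether any group at this place would give a measurable number.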